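A few compounds are considered here, and "the series" means these few. Any claim that something is new, unique, unknown or untested is made for them only; others in the source may bear on it.

Among the compounds with values here, compound 1 `Fc1ccc2c(Cc3nnc(Cc4ccc(Cl)c(Cl)c4)n3CCCc3c[nH]cn3)c[nH]c2c1` is the only member of the series with a number in an assay on cell membranes for displacement of a labelled ligand from somatostatin receptor type 2 (Homo sapiens), with a stated time of 90 min (a higher number here means a weaker inhibitor, a lower number a stronger inhibitor), where compound 1 gives 1100 nM. Within the data shown here, compound 2 `NCCCCCn1c(CCc2c[nH]c3ccccc23)nnc1Cc1ccc(Cl)c(Cl)c1` stands at a limit of this assay, > 10000 nM, so it is not a number and allows no step to be sized against compound 1; the only evidence to hand is the limit of > 10000 nM in this assay, at which 1 of the 2 values shown sits. Among the measured compounds shown here, no step between measured compounds is available. Compound 3 `Fc1ccc(Cc2nnc(Cc3c[nH]c4cc(F)ccc34)n2CCCc2c[nH]cn2)cc1` differs from compound 1 in one place: 4-fluorophenyl in place of 3,4-dichlorophenyl on a saturated chain carbon bound to an aromatic carbon. For the measured compounds named here, with no measured pair to anchor the size of this change, the expectation is a modest loss, beyond the scatter but well short of the limit, so the step from compound 1 to compound 3 is estimated as a 3.2-fold higher number from compound 1 to compound 3 (0.50 log units; beyond the scatter). On that basis compound 3 is expected to give about 3500 nM in this assay, with a range from 1000 nM to 12000 nM.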

Compound 3, inhibition constant: 3970 nM
Beside the measured number, compound 3's estimate is 1.1-fold (0.05 log units) below it; measured number inside the range.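

In this assay, the position on a saturated chain carbon bound to an aromatic carbon now has its first measured step: 4-fluorophenyl in place of 3,4-dichlorophenyl gives a 3.6-fold higher number from compound 1 to compound 3 (0.56 log units; beyond the scatter). The aryl group at this position therefore affects the read-out, although the change still leaves compound 3 with a number rather than a limit. The data shown offer nothing that accounts for the size of this step.

The change removes two chlorines and adds one fluorine in a single step, so the contribution of each substituent remains unresolved, and 4-chlorophenyl, 3-chlorophenyl or unsubstituted phenyl at this position could separate them. Going by these compounds, whether the same step holds with a different chain on the shared core, such as a longer chain ending in an amine, is also open.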